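Dimethoxybenzyl Swap on the Fluorinated Amide

The compounds below may be only part of what the source reports. "The series", "measured", "known", "first", "only" and "open" are said of these compounds alone.

Compound 3 `O=C(NCc1cn(Cc2ccc(F)cc2)nn1)c1cn(-c2ccccc2)nc1-c1ccc(F)cc1` stands at the high end of the three numbers in hand: in a functional assay on MCF7 cells (Homo sapiens) for antiproliferative activity, read by sulforhodamine B assay, with a stated time of 48 h (on this read-out higher numbers stand for weaker inhibition of growth and lower numbers for stronger inhibition of growth), compound 3 gives 55300 nM, the highest value of the set. Its parent compound 1 `O=C(NCc1cn(Cc2ccc(F)cc2)nn1)c1cn(-c2ccccc2)nc1-c1ccccc1` gives 7000 nM in this assay, and the step of a 7.9-fold higher number from compound 1 to compound 3 (0.90 log units; beyond the scatter) shows the cost of the added fluoro. Compound 2 `COc1cc(Cn2cc(CNC(=O)c3cn(-c4ccccc4)nc3-c3ccccc3)nn2)cc(OC)c1` gives 2400 nM, and the step of a 2.9-fold lower number from compound 1 to compound 2 (0.46 log units; beyond the scatter) shows what a dimethoxyphenyl in place of the 4-fluorophenyl did on the unfluorinated core.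

Compound 4 `COc1ccc(Cn2cc(CNC(=O)c3cn(-c4ccccc4)nc3-c3ccc(F)cc3)nn2)cc1OC` differs from compound 3 by 3,4-dimethoxyphenyl in place of 4-fluorophenyl on a saturated chain carbon bound to an aromatic nitrogen. Among the measured compounds shown here, the step that bears on it is the one from compound 1 to compound 2, which moved the number down modestly; the dimethoxy pattern there is not the same as in compound 4, so the transfer is loose. A modest lowering beyond the scatter is expected, a 2.8-fold lower number from compound 3 to compound 4 (0.44 log units; beyond the scatter), not a recovery to the level of compound 2.

Compound 4 is therefore expected to give about 20000 nM in this assay, within a range of 7000 nM to 60000 nM.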

Compound 4, concentration for 50% growth inhibition: > 100000 nM
Compound 4 ended at the assay's limit (the forecaster's own chance of this, stated with the estimate: 5%); middle value at least 5.0-fold (0.69 log units) away from the limit.
By their numbers in this assay, from the lowest: compound 2; then compound 1; then compound 3. At a limit, above all of these: compound 4.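

In this assay compound 4 stands at a limit and not at a number: the limit of > 100000 nM in this assay, at which 1 of the 4 values shown sits. Going by these compounds, the change can be read only as a floor, an at least 1.8-fold higher number from compound 3 to compound 4 (0.25 log units; that floor lies within the scatter), and its true size at this position stays unknown. With the core of compound 3, the 3,4-dimethoxyphenyl brings no lowering of the number, unlike the step of a 2.9-fold lower number from compound 1 to compound 2 (0.46 log units; beyond the scatter), so a dimethoxyphenyl at this position does not lower the number on both cores, although the two dimethoxy patterns differ.

The compounds shown leave open whether the dimethoxy pattern or the fluoro on the core sets this outcome, as each step changes the benzyl group on one core only. A 4-methoxybenzyl or a benzyl carrying a carboxylic acid at this position would widen the comparison.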